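Piperazine cap change in the chalcone-triazole series

The compounds below may be only part of what the source reports. "The series", "measured", "known", "first", "only" and "open" are said of these compounds alone.

Measured so far in a functional assay on MCF7 cells (Homo sapiens) for inhibition, read by MTT assay; on this read-out higher numbers stand for weaker inhibition and lower numbers for stronger inhibition:
Compound 1 `CCCCCCCCn1cc(/C=C/C(=O)c2ccc(NC(=O)CN3CCN(C(=O)OC(C)(C)C)CC3)cc2)nn1`: 98400 nM
Compound 2 `COc1ccccc1N1CCN(CC(=O)Nc2ccc(C(=O)/C=C/c3cn(Cc4ccc(Br)cc4)nn3)cc2)CC1`: 36800 nM
Compound 3 `O=C(CN1CCN(c2ccccc2)CC1)Nc1ccc(C(=O)/C=C/c2cn(Cc3ccc(Br)cc3)nn2)cc1`: 49200 nM

Compound 3 stands second highest of the three numbers in this assay. Going by the values given here, its nearest neighbour is compound 2, and the one step measured, a 1.3-fold higher number from compound 2 to compound 3 (0.13 log units; within the scatter), lies within the scatter. Compound 1 sits at the other end, and the gap from compound 3 to compound 1 is also within the scatter, so the three measured values do not separate from one another.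

The next compound is compound 4 `CC(C)(C)OC(=O)N1CCN(CC(=O)Nc2ccc(C(=O)/C=C/c3cn(Cc4ccc(Br)cc4)nn3)cc2)CC1`. It differs from compound 3 by tert-butoxycarbonyl in place of phenyl on an amine nitrogen in a ring. Among the compounds with values here, no measured step isolates this change. Compound 1 carries the same tert-butoxycarbonyl group on the ring nitrogen but also differs from compound 3 in the substituent on the triazole, so its value speaks only loosely to the change. What the numbers show is that all three measured compounds fall in the same weak band. The expectation for compound 4 is therefore a step of a 1.5-fold higher number from compound 3 to compound 4 (0.18 log units; within the scatter), not beyond the scatter, toward the value of compound 1. Compound 4 is estimated at 75000 nM, within a range of 35000 nM to 180000 nM.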

Compound 4, half-maximal inhibitory concentration: 31000 nM
Beside the measured number, compound 4's estimate is 2.4-fold (0.38 log units) above it; the measured number lies below the stated range.
By their numbers in this assay, from the lowest: compounds 4, 2, 3 and 1 (each within the scatter of the next, the first and the last beyond it).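

In this assay, tert-butoxycarbonyl on the amine nitrogen in the ring replaces phenyl with a 1.6-fold lower number from compound 3 to compound 4 (0.20 log units; within the scatter) and replaces 2-methoxyphenyl with a 1.2-fold lower number from compound 2 to compound 4 (0.07 log units; within the scatter), so groups with and without an aromatic ring are not told apart at this position. Going by these compounds alone, the one step beyond the scatter comes from the other place: with tert-butoxycarbonyl held constant, 4-bromophenyl in place of heptyl on the saturated chain carbon bound to an aromatic nitrogen gives a 3.2-fold lower number from compound 1 to compound 4 (0.50 log units; beyond the scatter), a modest gain. No supporting data bear on the reason for either result.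

On these data alone, whether an acetyl group, a carboxylic acid or a free amine on the ring nitrogen would leave this weak band remains open. So does whether a benzyl group lacking the bromine would hold the gain seen over heptyl.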